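Bromo in place of iodo in a small series

This account rests on a few compounds, and the source may have more. Where it says the series, first, only, none or still open, it means among the compounds named here.

In a functional assay on HUVEC cells (Homo sapiens), read by BrdU incorporation, with a stated time of 72 h (a higher number here means a weaker inhibitor, a lower number a stronger inhibitor), compound 1 (`Cc1ccc2nc(Cl)c(/C=C/C(=O)c3ccc(Cl)s3)cc2c1`) gives 59.4 nM and compound 2 (`Cc1ccc2cc(/C=C/C(=O)c3ccc(I)s3)c(Cl)nc2c1`) gives 135 nM as the higher of the two numbers, a gap beyond the usual scatter. These two compounds differ in more than one place, so the gap cannot be tied to a single change. Compound 3 (`Cc1ccc2cc(/C=C/C(=O)c3ccc(Br)s3)c(Cl)nc2c1`) departs from compound 2 at one place only: bromo in place of iodo on an aromatic carbon, with bromo in place of iodo on an aromatic carbon, turning 5-iodothiophen-2-yl into 5-bromothiophen-2-yl. Among the compounds with values here, no measured pair shows this change alone. Within the data shown here, the only other reference is compound 1 at 59.4 nM, so a small shift towards lower numbers is expected. The estimated step of a 1.3-fold lower number from compound 2 to compound 3 (0.11 log units; within the scatter) stays within the scatter. For compound 3 the estimate is 105 nM, with a range of 50 nM to 220 nM expected across repeat measurements.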

Compound 3, half-maximal inhibitory concentration: 83.6 nM
Compound 3: the middle estimate sits 1.3-fold (0.10 log units) above what was measured; measured number inside the range.
By their numbers in this assay, from the lowest: compounds 1, 3 and 2 (each within the scatter of the next, the first and the last beyond it).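

In this assay, within the data shown here, compound 3 gives the first comparison in which only the group at this position changes, and the step is a 1.6-fold lower number from compound 2 to compound 3 (0.21 log units; within the scatter) on going from 5-iodothiophen-2-yl to 5-bromothiophen-2-yl. At this carbon next to the ring sulfur, iodo and bromo therefore cannot be told apart in this read-out on the core of compound 2. Nothing at hand offers a reason for the size of this step.

From the compounds shown here alone, it remains open how this position would respond to a group other than a halogen, such as an amine, a methoxy group or a nitrile. Chloro at this position appears only in compound 1, whose core also differs, so the result of chloro alone on the core of compound 2 is unknown.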